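Swapping the aryl group on the pyridazinone core

The source may hold more compounds than are shown below. What is called first, only, known or untested is meant among the compounds shown, and "the series" means these compounds.

Compound 1 `Cc1cc(=O)n(-c2ccccc2C(F)(F)F)nc1C(=O)Nc1ccc(Oc2ncnc3ccsc23)c(F)c1` and compound 2 `Cc1cc(=O)n(-c2ccc(Br)cc2F)nc1C(=O)Nc1ccc(Oc2ncnc3ccsc23)c(F)c1` share one core; compound 3 `Cc1cc(=O)n(-c2ccccc2C(F)(F)F)nc1C(=O)Nc1ccc(Oc2ncnc3sccc23)cc1` and compound 4 `Cc1cc(=O)n(-c2ccc(Br)cc2F)nc1C(=O)Nc1ccc(Oc2ncnc3sccc23)cc1` share another. The difference between the two cores is not broken down here. In a functional assay on A549 cells (Homo sapiens) for cytotoxicity, read by MTT assay, with a stated time of 72 h (on this read-out higher numbers stand for weaker inhibition and lower numbers for stronger inhibition), compound 1 gives 4680 nM and compound 2 gives 2980 nM; the change 4-bromo-2-fluorophenyl in place of 2-(trifluoromethyl)phenyl on an aromatic nitrogen brought a 1.6-fold lower number from compound 1 to compound 2 (0.20 log units; within the scatter). In this assay compound 3 gives 19900 nM, the highest of the three numbers, beyond the scatter from both others. Compound 4 carries the same change, (4-bromo-2-fluorophenyl in place of 2-(trifluoromethyl)phenyl on an aromatic nitrogen), on the core of compound 3. The step is expected to be a 1.5-fold lower number from compound 3 to compound 4 (0.18 log units; within the scatter), resting on the step from compound 1 to compound 2. Compound 4 is therefore estimated at 13000 nM in this assay, between 5000 nM and 32000 nM.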

Compound 4, half-maximal inhibitory concentration: 12800 nM
Beside the measured number, compound 4's estimate is 1.0-fold (0.01 log units) above it, and the stated range covers the measured number.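

In this assay, putting 4-bromo-2-fluorophenyl in place of 2-(trifluoromethyl)phenyl on the core of compound 3 brought a 1.6-fold lower number from compound 3 to compound 4 (0.19 log units; within the scatter). Set beside the earlier step, the change reads alike on the two cores: the same change on two cores in this assay, a 1.6-fold lower number (0.20 log units; within the scatter) from compound 1 to compound 2 and a 1.6-fold lower number (0.19 log units; within the scatter) from compound 3 to compound 4, 1.0-fold (0.00 log units) apart, within the scatter of two such steps

Among these compounds, since each step lies within the scatter, this shows only that the change moved the number beyond the scatter on neither core; it does not show a real gain from the change, nor that the agreement would hold on any further core. As far as these compounds go, how a plain phenyl, a methoxyphenyl or a cyclohexyl group would read on the same aromatic nitrogen stays open. So does which part of the difference between the two cores accounts for the gap between their numbers.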